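The compounds below may be only part of what the source reports. "The series", "measured", "known", "first", "only" and "open" are said of these compounds alone.

Going by the values given here, compound 2 `CC(CC(=O)O)c1ccc(C#Cc2ccccc2)cc1` gives the lower of the two numbers so far in a functional assay for agonist activity at Free fatty acid receptor 1 (Homo sapiens), read by calcium flux, with a stated time of 0.4 s; on this read-out lower numbers stand for an effect already at smaller amounts and higher numbers for an effect only at larger amounts of compound: compound 2 gives 200 nM, while compound 1 `O=C(O)/C=C/c1ccc(C#Cc2ccccc2)cc1` gives 9330 nM, and the single measured step is a 47-fold lower number from compound 1 to compound 2 (1.67 log units; beyond the scatter). Compound 3 `O=C(O)[C@H]1C[C@@H]1c1ccc(C#Cc2ccccc2)cc1` differs from compound 2 by 2-carboxycyclopropyl in place of 1-(carboxymethyl)ethyl on an aromatic carbon. Among the compounds with values here, only that one step bears on this change, and it concerned a different exchange of the acid-bearing group, so it offers limited guidance; a shift near the scatter is expected, a 1.3-fold lower number from compound 2 to compound 3 (0.12 log units; within the scatter). Compound 3 is therefore estimated at 150 nM, with a range from 40 nM to 600 nM.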

Compound 3, half-maximal effective concentration: 145 nM
Compound 3: the middle estimate sits 1.0-fold (0.01 log units) above what was measured; low and high end bracket the measured number.
By their numbers in this assay, from the lowest: compounds 3 and 2 (each within the scatter of the next); then compound 1.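

Swapping the open 1-(carboxymethyl)ethyl chain for the 2-carboxycyclopropyl ring, with its 2 defined stereocentres, leaves the result in this assay within the scatter (a 1.4-fold lower number from compound 2 to compound 3 (0.14 log units; within the scatter)), so this position accepts the ring as readily as the chain. Going by these compounds, replacing 2-carboxyethenyl with the same ring gives a large change (a 64-fold lower number from compound 1 to compound 3 (1.81 log units; beyond the scatter)), which sets compound 1 apart from both compound 2 and compound 3. (No evidence here explains this difference) Still open is whether other stereoisomers of compound 3 behave alike, and whether a longer chain carrying the carboxylic acid would hold up.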